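A few compounds are considered here, and "the series" means these few. Any claim that something is new, unique, unknown or untested is made for them only; others in the source may bear on it.

Compounds measured in a functional assay on MCF7 cells (Homo sapiens) for inhibition; a lower number here means a stronger inhibitor, a higher number a weaker inhibitor:
- compound 1, `N#CC1CN1C(=O)NCc1ccccc1`, giving 6000 nM
- compound 2, `CCCCNC(=O)N1CC1C#N`, giving 6700 nM
- compound 3, `N#CC1CN1C(=O)NC1CCCCC1`, giving 8900 nM

All three share a core carrying a nitrile, and differ only in the group on the urea nitrogen. In this assay compound 2 sits close to both of its companions: its number lies within the usual scatter of compound 1 and also within the scatter of compound 3, so the three numbers cannot be told apart with confidence.

Compound 4, `CC(C)(C)NC(=O)N1CC1C#N`, has not yet been measured. It differs from compound 2 in one place: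

tert-butyl in place of butyl on an amide-type nitrogen

The same four carbons are present, joined differently. Going by the values given here, no measured pair shows what such a rearrangement does here, and the three measured values give no lead in either direction. The step from compound 2 to compound 4 is therefore expected to be small, a 1.0-fold higher number from compound 2 to compound 4 (0.02 log units; within the scatter), not beyond the scatter. Compound 4 is estimated at 7000 nM, with a range from 3000 nM to 16000 nM.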

Compound 4, half-maximal inhibitory concentration: 190000 nM
The estimate for compound 4 lay 27-fold (1.43 log units) below the measured number, outside the stated range (above it).
By their numbers in this assay, from the lowest: compounds 1, 2 and 3 (each within the scatter of the next); then compound 4.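

In this assay the three earlier compounds gave no sign that the group on this nitrogen mattered much, but this single change produces a 28-fold higher number from compound 2 to compound 4 (1.45 log units; beyond the scatter) and so shows that it can matter a great deal. Butyl and tert-butyl carry the same carbons on an amide-type nitrogen, so what separates compound 2 from compound 4 is how those carbons are joined, not how many there are. No measurement shown here explains why this rearrangement weakens inhibition so sharply. As far as these compounds go, it remains open where along the way from butyl to tert-butyl the loss sets in: isopropyl or sec-butyl on the same nitrogen would speak to that, and a longer chain such as hexyl would show whether extending the butyl chain changes the number at all.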